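This account rests on a few compounds, and the source may have more. Where it says the series, first, only, none or still open, it means among the compounds named here.

Measured compounds:
- compound 1 `CC(C(=O)N1CCN(c2ccccc2)CC1)N1C(=O)CCC1=O`, giving 50% in a functional assay on the whole organism (strain Swiss) with Mus musculus as the target, in the maximal electroshock model, with a stated time of 1 h, at a dose of 300 mg/kg by the intraperitoneal route; on this read-out lower numbers stand for a weaker effect and higher numbers for a stronger effect at the one dose given
- compound 2 `CC(C(=O)N1CCN(c2ccccc2Cl)CC1)N1C(=O)CCC1=O`, giving 25% in this assay
- compound 3 `CCC(C(=O)N1CCN(c2cccc(Cl)c2)CC1)N1C(=O)CCC1=O`, giving 100% in this assay

Compound 3 gives the highest of the three numbers. The nearest to it is compound 1, whose number is lower by a gap beyond the scatter, and the furthest is compound 2, whose number is lower still. Within the data shown here, the only step between compounds that differ in one place is a number 25 percentage points lower from compound 1 to compound 2 (beyond the scatter), a change of chloro in place of hydrogen on an aromatic carbon.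

Compound 4 `CC(C(=O)N1CCN(c2cccc(Cl)c2)CC1)N1C(=O)CCC1=O` has not yet been measured in this assay. It differs from compound 3 by hydrogen in place of methyl on a saturated chain carbon, two bonds along the chain from an amide-type nitrogen in a ring and a carbonyl carbon. Among the measured compounds shown here, no measured step shows this change: the step from compound 1 to compound 2 concerns a chloro substituent, and compounds 1 and 3 differ in two places, so no single step can be drawn between them. What the numbers do show is that compound 1 and compound 2, both carrying methyl at this chain position, give lower numbers than compound 3, which carries ethyl. On that thin basis a moderate fall is expected, a number 30 percentage points lower from compound 3 to compound 4 (beyond the scatter). Compound 4 is therefore estimated to give 70%, with a range from 35% to 100%.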

Compound 4, a percentage reported as activity, at one dose (the size of the read-out at that dose, not a potency): 75%
Compound 4: the middle estimate sits 5 percentage points below what was measured, and the stated range covers the measured number.
By their numbers in this assay, from the lowest: compound 2; then compound 1; then compound 4; then compound 3.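

The chain position now has a reading of its own: in this assay, with the 3-chlorophenyl group held fixed, the difference of ethyl to methyl gives a number 25 percentage points lower from compound 3 to compound 4 (beyond the scatter). The chloro change also proves to depend on where the chloro stands, since chloro in place of hydrogen gives a number 25 percentage points lower from compound 1 to compound 2 (beyond the scatter) in one place but a number 25 percentage points higher from compound 1 to compound 4 (beyond the scatter) in the other, and 3-chlorophenyl in place of 2-chlorophenyl on the amine nitrogen in a ring gives a number 50 percentage points higher from compound 2 to compound 4 (beyond the scatter). No supporting measurement is available to explain any of these differences.

The compounds shown leave open whether a propyl chain at this carbon would extend the rise seen with ethyl, and whether the difference of ethyl to methyl would keep its size with phenyl or 2-chlorophenyl in place of 3-chlorophenyl. They also leave open how a methoxy or trifluoromethyl group in place of chloro on the aromatic ring would read in this assay, which gives the size of the effect at a single dose and not a potency.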